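A few compounds are considered here, and "the series" means these few. Any claim that something is new, unique, unknown or untested is made for them only; others in the source may bear on it.

Among the compounds with values here, compound 1 `COc1ccc(-c2ccc3c(c2)C(=O)C(=O)N3Cc2ccc(Cl)c(Cl)c2)cc1` and compound 2 `COc1ccc(CN2C(=O)C(=O)c3cc(-c4ccc(F)cc4)ccc32)cc1` share one core and differ from each other at more than one place, so no single step separates them. In a functional assay on HepG2 cells (Homo sapiens) for antiproliferative activity, read by MTT assay, with a stated time of 48 h (a higher number here means a weaker inhibitor, a lower number a stronger inhibitor), compound 1 gives 990 nM, while compound 2 gives 3150 nM, the higher of the two numbers. Compound 3 `COc1ccc(CN2C(=O)C(=O)c3cc(-c4ccc(O)cc4)ccc32)cc1` is compound 2 with hydroxy in place of fluoro on an aromatic carbon. Within the data shown here, no measured pair isolates this change, so its size cannot be read from the series. The expected step of a 1.1-fold lower number from compound 2 to compound 3 (0.02 log units; within the scatter) is none beyond the scatter. Compound 3 is therefore estimated at 3000 nM, within 1000 nM to 9000 nM.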

Compound 3, half-maximal inhibitory concentration: > 10000 nM
Compound 3: a limit, no number; the forecaster's own chance of this, stated with the estimate: 5%; middle value at least 3.3-fold (0.52 log units) from the limit.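

In this assay, the position on the aromatic carbon para to a large group proves sensitive to the change from 4-fluorophenyl to 4-hydroxyphenyl, with an at least 3.1-fold higher number from compound 2 to compound 3 (0.50 log units; beyond the scatter). Compound 1 and compound 2 differ at more than one place, so they could not show this. Compound 3 reads as a limit and not a number, so the full size of the step stays unknown: the limit of > 10000 nM in this assay, at which 1 of the 3 values shown sits.

On these data alone, whether an amine or a carboxylic acid at this position would behave as hydroxy does stays open. Also open, as far as these compounds go, is how far the step depends on the other substituent on the shared core.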